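Aryl amide series: removing the pyrrolidine from compound 2

A few compounds are considered here, and "the series" means these few. Any claim that something is new, unique, unknown or untested is made for them only; others in the source may bear on it.

Measured so far in an assay on cells for inhibition of MAP kinase-interacting serine/threonine-protein kinase 1 (Homo sapiens), read by mobility shift assay, with stated times of 10 min and 60 min, in the presence of a further agent that is not named here; a higher number here means a weaker inhibitor, a lower number a stronger inhibitor:
- compound 1 `CC(C)Oc1cc(-c2cncc(-c3cnn(C4COC4)c3)c2)ccc1C(N)=O` — 200 nM
- compound 2 `NC(=O)c1ccc(-c2cccnc2)cc1OC1CCNC1` — 1900 nM
- compound 3 `COc1cc(C(N)=O)ccc1-c1cccnc1` — 29300 nM

Among the three numbers, compound 2 holds the middle place. Compound 1 gives the lowest number, and the gap between compound 1 and compound 2 lies beyond the scatter. Compound 3 gives the highest number, and its gap to compound 2 is likewise beyond the scatter. So compound 2 is clearly separated from both of its neighbours, on opposite sides.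

The next compound, compound 4 `NC(=O)c1ccc(-c2cccnc2)cc1O`, is reached from compound 2 by a single change: hydrogen in place of pyrrolidin-3-yl on an oxygen on an aromatic ring. The pyrrolidin-3-yl group, with its one hydrogen-bond donor and one hydrogen-bond acceptor, is gone and only a hydroxy remains on the shared core.

Among the compounds with values here, no measured pair in this set shares this same change, so the size of the step has no direct precedent. What the numbers do show is that compound 3, with a methoxy in the same region, sits far above compound 2, and compound 4 carries even less in that region than compound 3. The expectation is therefore a step upward, beyond the scatter, from compound 2 to compound 4, a 7.9-fold higher number from compound 2 to compound 4 (0.90 log units; beyond the scatter). Compound 4 is estimated at 15000 nM, with a range from 4000 nM to 60000 nM.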

Compound 4, half-maximal inhibitory concentration: 4300 nM
The estimate for compound 4 lay 3.5-fold (0.54 log units) above the measured number, and the stated range covers the measured number.
By their numbers in this assay, from the lowest: compound 1; then compound 2; then compound 4; then compound 3.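

In this assay hydrogen in place of pyrrolidin-3-yl on the oxygen on the aromatic ring gives a 2.3-fold higher number from compound 2 to compound 4 (0.35 log units; beyond the scatter) and this modest step is still beyond the scatter. With only a hydroxy at this place, compound 4 still reads 4300 nM and the pyrrolidin-3-yl group therefore accounts for only a modest part of the number of compound 2 on this shared core. Within the data shown here, no earlier pair could show this point. None differed at this oxygen alone. Nothing available on the compounds explains why the step is this small.

Still open, on these data alone, is whether the nitrogen of the pyrrolidin-3-yl group matters or whether its carbons alone would give the same number, which a cyclopentyl group on the same oxygen would separate. A longer chain ending in an amine, such as 2-aminoethyl, or a piperidin-4-yl group at this place would show whether the number of compound 2 can be lowered further on this core.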